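The compounds below may be only part of what the source reports. "The series", "measured", "known", "first", "only" and "open" are said of these compounds alone.

In a functional assay on MCF7 cells (Homo sapiens) for antiproliferative activity, read by MTT assay, with a stated time of 72 h (a higher number here means a weaker inhibitor, a lower number a stronger inhibitor), compound 1 `COc1ccc(N2C(=O)COc3ccc(-c4ccc(O)cc4)cc32)cc1` gives 17300 nM. Compound 2 `COc1cccc(N2C(=O)COc3ccc(-c4ccc(O)cc4)cc32)c1` reads > 40000 nM, which is a limit and not a number. Compound 3 `Cc1ccc(N2C(=O)COc3ccc(-c4cnc5ccccc5c4)cc32)cc1` reads > 40000 nM, which is also a limit. Compound 2 therefore has no exact value and stands at the limit of > 40000 nM in this assay, at which 2 of the 3 values shown sit.

The next structure is compound 4 `O=C1COc2ccc(-c3ccc(O)cc3)cc2N1`, which differs from compound 2 by hydrogen in place of 3-methoxyphenyl on an amide-type nitrogen in a ring. Among the measured compounds shown here, one measured step bears on this nitrogen, an at least 2.3-fold higher number from compound 1 to compound 2 (0.36 log units; beyond the scatter), and it swaps one methoxyphenyl group for the other. For the measured compounds named here, that step shows that the group at this place can shift the reading by a modest amount, but no measured compound carries hydrogen there, so the guidance is weak.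

A modest step toward a lower number is expected, with the reading staying close to the limit, and this expected change is an at least 1.2-fold lower number from compound 2 to compound 4 (0.09 log units; that floor lies within the scatter). The estimated value for compound 4 is 32000 nM, with an expected range from 14000 nM to 70000 nM.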

Compound 4, half-maximal inhibitory concentration: > 40000 nM
Compound 4 ended at the assay's limit; the forecaster's own chance of this, stated with the estimate: 55%; at least 1.2-fold (0.09 log units) between middle value and limit.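

In this assay compound 4 reads > 40000 nM, which is a limit. Replacing the 4-methoxyphenyl group on the ring nitrogen with hydrogen gives an at least 2.3-fold higher number from compound 1 to compound 4 (0.36 log units; beyond the scatter), so this nitrogen does not keep its exact reading once that group is gone, and of the three groups seen there with the rest of the molecule unchanged, only 4-methoxyphenyl gives an exact value. The step between the 3-methoxyphenyl and hydrogen compounds cannot be read, and most of the set now sits at one ceiling: the limit of > 40000 nM in this assay, at which 3 of the 4 values shown sit.

On these data alone, it remains open whether a small methyl group, a longer chain or a chain ending in an amine on this nitrogen would bring the reading under the limit. As far as these compounds go, how far apart compound 2 and compound 4 truly lie also stays unknown.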